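Adding chloro to a compound that sits at a limit

The compounds below may be only part of what the source reports. "The series", "measured", "known", "first", "only" and "open" are said of these compounds alone.

Compound 1 `Cc1ccc(-c2c(CNC(C)(C)C)c(C(=O)O)nn2-c2ccccc2)cc1` is the starting point. In a functional assay on NCI-H460 cells (Homo sapiens) for inhibition, read by sulforhodamine B assay, with a stated time of 48 h (on this read-out higher numbers stand for weaker inhibition of growth and lower numbers for stronger inhibition of growth), compound 1 gives > 688000 nM as its result, which is a limit and not a number. Compound 2 `COc1ccc(-c2c(CNC(C)(C)C)c(C(=O)O)nn2-c2ccccc2)cc1` carries methoxy in place of methyl and gives > 659000 nM as a limit too. Compound 3 `CC(C)(C)NCc1c(C(=O)O)nn(-c2ccccc2)c1-c1ccc([N+](=O)[O-])cc1` carries nitro in place of methyl and gives > 634000 nM as a limit too. Compound 1 therefore stands among limits, without a number of its own, and no order can be drawn among these three.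

Compound 4 `Cc1ccc(-c2c(CNC(C)(C)C)c(C(=O)O)nn2-c2ccc(Cl)cc2)cc1` differs from compound 1 by a single change. That change chloro in place of hydrogen on an aromatic carbon puts chloro in place of hydrogen on an aromatic carbon, para to a large group, so that phenyl becomes 4-chlorophenyl. The measured steps that bear on it are a step that the two limits leave unreadable from compound 1 to compound 2 together with a step that the two limits leave unreadable from compound 1 to compound 3 and also a step that the two limits leave unreadable from compound 2 to compound 3 and none of them has a readable size. None of them touches that phenyl either. With no size to carry over, no step beyond the usual scatter is expected in this assay in either direction. The expected move is an at least 1.1-fold lower number from compound 1 to compound 4 (0.05 log units; that floor lies within the scatter) as estimated here. Compound 4 is estimated at 600000 nM with an expected range from 200000 nM to 900000 nM and may well sit at a limit again.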

Compound 4, concentration for 50% growth inhibition: > 629000 nM
Compound 4: a limit, no number (the forecaster's own chance of this, stated with the estimate: 75%); middle value at least 1.0-fold (0.02 log units) from the limit.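

In this assay compound 4 gives > 629000 nM, which is a limit and not a number, and compound 1 also sits at a limit, so the step between them cannot be read. The compounds shown leave open whether chloro, or any other change among them, alters growth inhibition at all, as all four results are limits.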